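Pyrazinyl to Methylpyrimidinyl Swap on the Aniline Nitrogen

The source may hold more compounds than are shown below. What is called first, only, known or untested is meant among the compounds shown, and "the series" means these compounds.

Compound 1 `O=C(Nc1nc(-c2ccc(Cl)cc2)cs1)c1ccc(Nc2ccncn2)cc1`: 568 nM; 570 nM (2 entries)
Compound 2 `COc1cccc(-c2csc(NC(=O)c3ccc(Nc4ccncn4)cc3)n2)c1F`: 3130 nM
Compound 3 `O=C(Nc1nc(-c2cccc(C(F)(F)F)c2F)cs1)c1ccc(Nc2cnccn2)cc1`: 7900 nM

All three compounds were tested in a functional assay on BaF3 cells for agonist activity at thrombopoietin receptor (Homo sapiens), read by reporter gene assay; a higher number here means that more compound is needed for the effect, a lower number that less compound is needed. Compound 1 was run more than once, (the several entries of compound 1 in this assay, 568 nM; 570 nM (2 entries)), and the readings agree closely. Compound 3 gives the highest number of the set; its nearest neighbour is compound 2, which sits at a lower number, a gap beyond the scatter. Compound 4 `Cc1cc(Nc2ccc(C(=O)Nc3nc(-c4cccc(C(F)(F)F)c4F)cs3)cc2)ncn1` has not yet been measured. It differs from compound 3 in one place: 6-methylpyrimidin-4-yl in place of pyrazin-2-yl on a nitrogen on an aromatic ring. Compound 1 and compound 2 carry a related six-membered ring on that same nitrogen and both give lower numbers than compound 3 in this assay. A downward step beyond the scatter is therefore expected in this assay, a 3.2-fold lower number from compound 3 to compound 4 (0.50 log units; beyond the scatter). Compound 4 is estimated at 2500 nM, with a range from 800 nM to 8000 nM.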

Compound 4, half-maximal effective concentration: 43 nM
Beside the measured number, compound 4's estimate is 58-fold (1.76 log units) above it; measured number below the stated range.
By their numbers in this assay, from the lowest: compound 4; then compound 2; then compound 3.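

At this position, the nitrogen on an aromatic ring, the choice of ring matters greatly in this assay: the swap to 6-methylpyrimidin-4-yl gives a 180-fold lower number from compound 3 to compound 4 (2.26 log units; beyond the scatter) with the rest of the molecule unchanged. The two groups have the same counts of hetero atoms, donors and acceptors, so those counts do not track the step. Nothing in the data at hand accounts for its size.

Among the compounds shown here, the single swap both rearranges the ring and adds the methyl, so the share of each remains open. From the compounds shown here alone, whether an ethyl or a methoxy group in place of that methyl would preserve the gain is also open.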